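The compounds below may be only part of what the source reports. "The series", "measured", "known", "first", "only" and "open" are said of these compounds alone.

Compound 1, with the structure `O=C(CI)NCCCNc1ncnc2c1ncn2[C@@H]1O[C@H](COP(=O)(O)OP(=O)(O)OP(=O)(O)O)[C@@H](O)[C@H]1O`, gives 0% in an assay on isolated protein for inhibition of hexokinase-2 (Rattus norvegicus), with a stated time of 6 h, tested at 10 mM; on this read-out higher numbers stand for more inhibition at the one concentration tested (going by the name of the read-out) and lower numbers for less inhibition. Compound 2, with the structure `O=C(CI)NCCCCCC(=O)NCCCNc1ncnc2c1ncn2[C@@H]1O[C@H](COP(=O)(O)OP(=O)(O)OP(=O)(O)O)[C@@H](O)[C@H]1O`, gives 0% in this assay, and the step of no change at the digits printed from compound 1 to compound 2 (within the scatter) was flat. Compound 2 therefore stands level with compound 1 at the digits printed. Compound 3, with the structure `O=C(CI)NCCCCCCC(=O)NCCCNc1ncnc2c1ncn2[C@@H]1O[C@H](COP(=O)(O)OP(=O)(O)OP(=O)(O)O)[C@@H](O)[C@H]1O`, differs from compound 2 by (((iodomethyl)carbonyl)amino)methyl in place of ((iodomethyl)carbonyl)amino on a saturated chain carbon, five bonds along the chain from a carbonyl carbon. For the measured compounds named here, the only measured step that bears on this, no change at the digits printed from compound 1 to compound 2 (within the scatter), altered the chain far more and still gave no change, so compound 3 is expected to give 0% in this assay, within 0% to 10%, meaning an expected step of no change at the digits printed from compound 2 to compound 3 (within the scatter).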

Compound 3, a percentage reported as inhibition, at one concentration (the size of the read-out at that concentration, not a potency): 0%
Compound 3: the middle estimate sits on the measured number at the digits printed; the range from low to high includes it.
By their numbers in this assay, from the lowest: compounds 1, 2 and 3 (each within the scatter of the next).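

In this assay, placing (((iodomethyl)carbonyl)amino)methyl in place of ((iodomethyl)carbonyl)amino gives no change at the digits printed from compound 2 to compound 3 (within the scatter), so this smaller change at this position is as flat as the larger one before it. The full change, 5-(((iodomethyl)carbonyl)amino)pentyl in place of iodo, likewise gives no change at the digits printed from compound 1 to compound 3 (within the scatter), which leaves three chain lengths without any difference. Nothing at hand explains this flat read-out. As far as these compounds go, whether a longer chain would give any inhibition remains open, as does whether an amine or a carboxylic acid in place of the iodomethyl carbonyl end would do so.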